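The source may report more compounds than this note shows. Statements on the series, on what has been measured and on what is new or still open speak of the compounds shown alone.

Working notes on the series. In a functional assay on 143B cells (Homo sapiens) for antiproliferative activity, read by MTT assay, with a stated time of 48 h (a higher number here means a weaker inhibitor, a lower number a stronger inhibitor), compound 3 `O=C(Nc1cccc(/C=C/C(=O)c2nc3ccccc3[nH]2)c1)c1cccc(C(F)(F)F)c1` gives 9570 nM, the highest of the three numbers, though none of the gaps exceeds the scatter. Compound 2 `Cc1ccccc1C(=O)Nc1cccc(/C=C/C(=O)c2nc3ccccc3[nH]2)c1` gives 8290 nM and compound 1 `O=C(Nc1cccc(/C=C/C(=O)c2nc3ccccc3[nH]2)c1)c1ccc(Br)cc1` gives 7310 nM. Each pair differs only in the aryl group on the carbonyl carbon, and every step so measured stayed within the scatter: a 1.1-fold higher number from compound 1 to compound 2 (0.05 log units; within the scatter), a 1.3-fold higher number from compound 1 to compound 3 (0.12 log units; within the scatter) and a 1.2-fold higher number from compound 2 to compound 3 (0.06 log units; within the scatter). Compound 4 `Cc1cc(C)cc(C(=O)Nc2cccc(/C=C/C(=O)c3nc4ccccc4[nH]3)c2)c1` repeats this kind of exchange: 3,5-dimethylphenyl in place of 3-(trifluoromethyl)phenyl on a carbonyl carbon. No step beyond the scatter is expected in this assay, in either direction, because a 1.1-fold higher number from compound 1 to compound 2 (0.05 log units; within the scatter), a 1.3-fold higher number from compound 1 to compound 3 (0.12 log units; within the scatter) and a 1.2-fold higher number from compound 2 to compound 3 (0.06 log units; within the scatter) all came from exchanges at the same carbonyl carbon. Compound 4 is therefore estimated at 8500 nM, within 4000 nM to 18000 nM, an expected step of a 1.1-fold lower number from compound 3 to compound 4 (0.05 log units; within the scatter).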

Compound 4, half-maximal inhibitory concentration: 4020 nM
Compound 4: middle estimate off by 2.1-fold (0.33 log units), on the high side; low and high end bracket the measured number.
By their numbers in this assay, from the lowest: compounds 4, 1, 2 and 3 (each within the scatter of the next, the first and the last beyond it).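

In this assay, exchange of the aryl group on the carbonyl carbon now moves the number beyond the scatter, with 3,5-dimethylphenyl entering in a 2.4-fold lower number from compound 3 to compound 4 (0.38 log units; beyond the scatter) and in a 2.1-fold lower number from compound 2 to compound 4 (0.31 log units; beyond the scatter). Against 4-bromophenyl the same group gives a 1.8-fold lower number from compound 1 to compound 4 (0.26 log units; within the scatter), so compound 4 remains unseparated from compound 1. Nothing available explains the steps with 3,5-dimethylphenyl.

Open, on these data alone, is whether 3-methylphenyl would be enough to give such a step. Also open, as far as these compounds go, is how an amine or a carboxylic acid on this aryl ring would behave.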